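Swapping the amide head group of a triazole antagonist

The compounds below may be only part of what the source reports. "The series", "measured", "known", "first", "only" and "open" are said of these compounds alone.

Two members of this series have been measured in a functional assay on CHO cells for antagonist activity at growth hormone secretagogue receptor type 1 (Homo sapiens); a lower number here means a stronger inhibitor, a higher number a weaker inhibitor. Compound 1 `CCc1ccc(-n2c(CCc3c[nH]c4ccccc34)nnc2[C@H](NC(=O)c2ccccn2)c2c[nH]c3ccccc23)cc1` gives 129 nM in this assay. Compound 2 `CCc1ccc(Cn2c(CCc3ccccc3)nnc2[C@H](NC(=O)Cc2ccccn2)c2c[nH]c3ccccc23)cc1` gives 124 nM in this assay, and these two values sit so close together that nothing separates them. As far as these compounds go, compound 3 `CCc1ccc(Cn2c(CCc3ccccc3)nnc2[C@H](NC(=O)Cc2cccnc2)c2c[nH]c3ccccc23)cc1` was also tested in this assay, but compound 3 has as its result only "not determined" (no result reported), so its position on the scale is unknown. Compound 4 `CCc1ccc(Cn2c(CCc3ccccc3)nnc2[C@H](NC(=O)c2cnccn2)c2c[nH]c3ccccc23)cc1` is the next compound to be measured in this assay. The change from compound 3 to compound 4 is pyrazin-2-yl in place of (pyridin-3-yl)methyl on a carbonyl carbon. No measured step of this kind exists among the compounds shown, so the size and direction of the move can only be guessed. Compound 1 carries its amide directly on an aromatic ring and gives 129 nM, and compound 2 carries an aromatic ring one carbon further from the carbonyl and gives 124 nM, so both arrangements land in the same region. For compound 4 a potency in that same region is expected, estimated at 150 nM with a likely range from 45 nM to 500 nM.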

Compound 4, antagonist equilibrium constant: 76 nM
For compound 4 the middle estimate is 2.0-fold (0.30 log units) above the measured one, within the range that was stated.
By their numbers in this assay, from the lowest: compounds 4, 2 and 1 (each within the scatter of the next).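

For the compounds shown here, this is the first reading at this position in which nothing else in the molecule changes. In this assay, pyrazin-2-yl in place of (pyridin-2-yl)methyl on the carbonyl carbon gives a step that stays within the scatter (a 1.6-fold lower number from compound 2 to compound 4 (0.21 log units; within the scatter)), so the amide can carry either head group with no measurable change in this read-out. No supporting measurement offers an explanation for this result.

The step from compound 3 cannot be read, since compound 3 has no number. As far as these compounds go, because the ring and the link to the carbonyl change together, the effect of each alone stays open, and a (pyrazin-2-yl)methyl group or a plain phenyl ring on the same carbonyl carbon would help separate them.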